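The compounds below may be only part of what the source reports. "The series", "measured", "known", "first", "only" and "open" are said of these compounds alone.

The measured compounds and their values:

Compound 1, `COc1ccc2oc(CSC(=S)N(C(C)C)C(C)C)cc(=O)c2c1` — > 25000 nM
Compound 2, `Cc1ccc2c(=O)c(CSC(=S)N3CCOCC3)coc2c1` — 20700 nM
Compound 3, `CC(C)N(C(=S)SCc1cc(=O)c2ccccc2o1)C(C)C` — 31700 nM

All three were tested in a functional assay on MCF7 cells (Homo sapiens) for antiproliferative activity, read by MTT assay, with a stated time of 72 h; on this read-out higher numbers stand for weaker inhibition and lower numbers for stronger inhibition. Compound 1 gives only a limit there, > 25000 nM, so its place on the scale is not a number but a boundary of the assay. Compound 3 in this assay gives 31700 nM, and compound 2 gives 20700 nM; the two sit close together.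

Among the measured compounds shown here, the one step that joins two measured compounds, a step that the limit leaves unreadable from compound 1 to compound 3, cannot be sized, because the limit of > 25000 nM in this assay, at which 1 of the 3 values shown sits, hides the starting point.

Compound 4, `COc1ccc2oc(CSC(=S)N3CCOCC3)cc(=O)c2c1`, is not yet measured. It differs from compound 1 in one place: morpholin-4-yl in place of diisopropylamino on a thiocarbonyl carbon. For the measured compounds named here, no measured pair shows this exchange on its own, and the only step that touches compound 1 is unreadable. The figures for compound 2 and compound 3 both lie in the same weak region, which gives no ground to expect a large movement in either direction; the exchange is expected to leave the value near where the measured compounds stand.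

Compound 4 is therefore expected to come in at about 22000 nM, with a plausible range from 8000 nM to 60000 nM, which means an estimated step of an at least 1.1-fold lower number from compound 1 to compound 4 (0.05 log units; that floor lies within the scatter).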

Compound 4, half-maximal inhibitory concentration: > 25000 nM
Compound 4 gave a limit, no number; the forecaster's own chance of this, stated with the estimate: 35%; middle value at least 1.1-fold (0.05 log units) from the limit.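

In this assay compound 4 gives > 25000 nM, which is a limit and not a number. Among the compounds shown here, no step from compound 1 to compound 4 can be read, because both compounds stop at the same limit: the limit of > 25000 nM in this assay, at which 2 of the 4 values shown sit. The compounds shown leave open whether morpholin-4-yl in place of diisopropylamino on a thiocarbonyl carbon moves the value at all, and in which direction.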